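Ester variation on the shared core: compound 4

The source may report more compounds than this note shows. Statements on the series, on what has been measured and on what is new or still open speak of the compounds shown alone.

Among the compounds with values here, compound 1 `CC/C=C\C[C@H]1C(=O)C=C[C@H]1CC(=O)OCCC` gives 35 uM in an ADME assay on RAW264.7 cells (Mus musculus) for cytotoxicity, read by MTT assay, with a stated time of 24 h (on this read-out higher numbers stand for lower toxicity in this test and lower numbers for higher toxicity in this test), the lowest of the three numbers so far. Compound 3 `CC/C=C\C[C@H]1C(=O)C=C[C@H]1CC(=O)Oc1ccc(O)cc1` sits nearest, at 49 uM in this assay, a gap within the scatter. Compound 2 `CC/C=C\C[C@H]1C(=O)C=C[C@H]1CC(=O)Oc1ccccc1` lies furthest, at 158 uM. The step of a 4.5-fold higher number from compound 1 to compound 2 (0.65 log units; beyond the scatter) is the largest seen, and a 3.2-fold lower number from compound 2 to compound 3 (0.51 log units; beyond the scatter) is of similar size. Compound 4 `CC/C=C\C[C@H]1C(=O)C=C[C@H]1CC(=O)OCCOCCOC` is not yet measured; it differs from compound 1 by 2-methoxyethoxy in place of methyl on a saturated chain carbon, two bonds along the chain from an oxygen next to a carbonyl group. Within the data shown here, all measured steps alter the same ester, but none extends a saturated chain, so their bearing is indirect; the closest precedent, a 1.4-fold higher number from compound 1 to compound 3 (0.15 log units; within the scatter), stayed within the scatter. For compound 4 the expected step is a 1.3-fold higher number from compound 1 to compound 4 (0.11 log units; within the scatter) in this assay, within the scatter. Compound 4 is estimated at 45 uM, range 20 uM to 100 uM.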

Compound 4, half-maximal toxic concentration: 161 uM
Beside the measured number, compound 4's estimate is 3.6-fold (0.55 log units) below it; measured number above the stated range.
By their numbers in this assay, from the lowest: compounds 1 and 3 (each within the scatter of the next); then compounds 2 and 4 (each within the scatter of the next).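

Lengthening the propyl to 2-(2-methoxyethoxy)ethyl shows that a saturated chain on the ester oxygen can move the number in this assay: a 4.6-fold higher number from compound 1 to compound 4 (0.66 log units; beyond the scatter) is a step beyond the scatter. A non-aromatic group can also match the phenyl ester, as a 1.0-fold higher number from compound 2 to compound 4 (0.01 log units; within the scatter) lies within the scatter. The hydroxy-bearing aromatic ester stays apart, with a 3.3-fold higher number from compound 3 to compound 4 (0.52 log units; beyond the scatter) also beyond the scatter.

From the compounds shown here alone, whether an amine, a carboxylic acid or a longer chain in place of 2-(2-methoxyethoxy)ethyl would keep this number remains open. No evidence on hand bears on the origin of this shift.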